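The source may report more compounds than this note shows. Statements on the series, on what has been measured and on what is new or still open speak of the compounds shown alone.

Three compounds share one core and differ only in the group attached to the carbamate at the end of the molecule. Compound 1 `Cc1c(Oc2ccc(/C=C3\SC(=O)NC3=O)cc2)ncnc1OC1CCN(C(=O)OCc2ccccc2)CC1` gives 805 nM in a functional assay on CHO-K1 cells for agonist activity at Glucose-dependent insulinotropic receptor (Homo sapiens), read by cAMP accumulation and immunoassay, with a stated time of 1 h; a higher number here means that more compound is needed for the effect, a lower number that less compound is needed; compound 2 `CCOC(=O)N1CCC(Oc2cc(Oc3ccc(/C=C4\SC(=O)NC4=O)cc3)ncn2)CC1` gives 790 nM; compound 3 `CC(C)(C)OC(=O)N1CCC(Oc2cc(Oc3ccc(/C=C4\SC(=O)NC4=O)cc3)ncn2)CC1` gives 130 nM, the lowest of the three numbers, with the nearest, compound 2, lying a step of a 6.1-fold lower number from compound 2 to compound 3 (0.78 log units; beyond the scatter) away. Among the measured compounds shown here, that step, tert-butyl in place of ethyl on an oxygen next to a carbonyl group, is the only single change with a measured size here, and it was beyond the scatter.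

Compound 4 `O=C1NC(=O)/C(=C/c2ccc(Oc3cc(OC4CCN(C(=O)OCc5ccccc5)CC4)ncn3)cc2)S1` is reached from compound 3 by benzyl in place of tert-butyl on an oxygen next to a carbonyl group. For the measured compounds named here, no measured step covers this exact exchange. Compound 1 also carries a benzyl at the same place, but it differs from compound 4 in a second position as well, so the value of compound 1, 805 nM, can only hint at the direction; it sits close to compound 2, not to compound 3. On that basis, the expected step of a 3.5-fold higher number from compound 3 to compound 4 (0.54 log units; beyond the scatter) from compound 3 to compound 4 is an increase in the number, with wide uncertainty. Compound 4 is estimated at 450 nM, within a range from 130 nM to 1500 nM.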

Compound 4, half-maximal effective concentration: 107 nM
Compound 4: the middle estimate sits 4.2-fold (0.62 log units) above what was measured; measured number outside the range, below it.
By their numbers in this assay, from the lowest: compounds 4 and 3 (each within the scatter of the next); then compounds 2 and 1 (each within the scatter of the next).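

In this assay, benzyl in place of tert-butyl on an oxygen next to a carbonyl group comes to a 1.2-fold lower number from compound 3 to compound 4 (0.08 log units; within the scatter), so this position takes one six-membered aromatic ring of carbon with no measurable difference from tert-butyl. Ethyl at the same place behaves differently: phenyl in place of methyl on a saturated chain carbon bound to an oxygen next to a carbonyl group comes to a 7.4-fold lower number from compound 2 to compound 4 (0.87 log units; beyond the scatter), which sets benzyl, like tert-butyl, clearly apart from ethyl. With benzyl held fixed, hydrogen in place of methyl on an aromatic carbon comes to a 7.5-fold lower number from compound 1 to compound 4 (0.88 log units; beyond the scatter), so the high number of the earlier benzyl compound goes with that methyl on the shared core and not with the benzyl itself.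

No measurement shown gives a reason for any of these steps. Still open, from the compounds shown here alone, is how a cyclohexylmethyl or a pyridylmethyl would fare on that oxygen, and whether the methyl on the aromatic carbon would give a similar step with tert-butyl in place of benzyl.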